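Trimming the Side Chain of Compound 1

The source may report more compounds than this note shows. Statements on the series, on what has been measured and on what is new or still open speak of the compounds shown alone.

Of the compounds shown here, three sharing one core have been measured in a functional assay on the whole organism (Tail, strain ICR) with Mus musculus as the target, in the tail flick test, with a stated time of 90 min, at a dose of 25 umol/kg by the oral route; a lower number here means a weaker effect, a higher number a stronger effect of the compound at the dose given. Compound 1 `N=C(N)NCCC[C@H](NC(=O)CN(c1nc(Cl)nc2[nH]cnc12)C1CC1)C(=O)O` gives 27.6%, the lowest of the three numbers, although each of the other two sits within the usual scatter of it. Compound 2 `N=C(N)NCCC[C@H](NC(=O)CN(c1nc(Cl)nc2[nH]cnc12)C1CC1)C(=O)OCc1ccccc1` gives 30.4%, and the change a number 2.8 percentage points higher from compound 1 to compound 2 (within the scatter) is within the scatter. Compound 3 `NCCCC[C@H](NC(=O)CN(c1nc(Cl)nc2[nH]cnc12)C1CC1)C(=O)OCc1ccccc1` gives 35.3%, and the change a number 4.9 percentage points higher from compound 2 to compound 3 (within the scatter) is likewise within the scatter.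

Compound 4 `C[C@H](NC(=O)CN(c1nc(Cl)nc2[nH]cnc12)C1CC1)C(=O)O` has not yet been measured. It differs from compound 1 by a hydrogen atom in place of a group of 6 heavy atoms (3 carbon, 3 nitrogen; no ring), on a saturated chain carbon, two bonds along the chain from an amide-type nitrogen and a carbonyl carbon. For the measured compounds named here, no measured step removes this chain entirely; the closest is the step from compound 2 to compound 3, which altered only the end of that chain and stayed within the scatter. Since neither measured step moved this assay beyond its scatter, no step beyond the scatter is expected here either, perhaps a slightly lower number. Compound 4 is therefore estimated at 24%, within a range from 10% to 40%, an expected step of a number 3.6 percentage points lower from compound 1 to compound 4 (within the scatter).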

Compound 4, a percentage reported as activity, at one dose (the size of the read-out at that dose, not a potency): 43.5%
Compound 4: middle estimate off by 19.5 percentage points, on the low side, outside the stated range (above it).
By their numbers in this assay, from the lowest: compounds 1, 2, 3 and 4 (each within the scatter of the next, the first and the last beyond it).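

For the compounds shown here, replacing the whole side chain with a hydrogen atom, on this saturated chain carbon, gives the first step in this assay that lies beyond the scatter, though a modest one: a number 15.9 percentage points higher from compound 1 to compound 4 (beyond the scatter). The earlier steps, which changed the acid end of the molecule or only the tip of the chain, did not show this; here the group of 6 heavy atoms is shown not to be needed for the effect at this dose, and losing it gives a higher number. The data hold nothing that explains why the number rises.

Still open, on these data alone, is whether a short chain at this carbon, such as an ethyl or a propyl group, would stay close to compound 4 or fall back towards compound 1. Also open, as far as these compounds go, is how a hydroxyl or a carboxylic acid at the end of such a chain, or a benzyl ester on compound 4, would read.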